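Adding a Methoxy Group Across Two Inactive Cores

A few compounds are considered here, and "the series" means these few. Any claim that something is new, unique, unknown or untested is made for them only; others in the source may bear on it.

Compound 1 `COc1ccc(-c2c[nH]c(=O)n2-c2cc(OC)c(OC)c(OC)c2)cc1` and compound 2 `COc1ccc(-c2c[nH]c(=O)n2-c2cc(OC)c(OC)c(OC)c2)cc1OC` share one core; compound 3 `COc1ccc(-c2cn(C(=O)Nc3cc(OC)c(OC)c(OC)c3)c(=O)n2-c2cc(OC)c(OC)c(OC)c2)cc1` and compound 4 `COc1ccc(-c2cn(C(=O)Nc3cc(OC)c(OC)c(OC)c3)c(=O)n2-c2cc(OC)c(OC)c(OC)c2)cc1OC` share another, and the difference between the two cores is not broken down here. Within each pair the change is the same, made twice in all: methoxy in place of hydrogen on an aromatic carbon in the first pair and methoxy in place of hydrogen on an aromatic carbon in the second, at a place described in identical words for both.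

In a functional assay on ECa-109 cells (Homo sapiens) for cytotoxicity, read by MTT assay, with a stated time of 48 h (on this read-out lower numbers stand for stronger inhibition and higher numbers for weaker inhibition), compound 1 reaches only the limit of the assay, > 50000 nM. Compound 2 likewise reaches only the limit, > 50000 nM. The step that the two limits leave unreadable from compound 1 to compound 2 therefore cannot be sized. Compound 3 also reaches only the limit, > 50000 nM. Every value obtained so far sits at the limit of > 50000 nM in this assay, at which 3 of the 3 values shown sit, so no direction of change can be read anywhere in this set.

Compound 4 has not yet been measured in this assay. The step from compound 3 to compound 4 is expected to remain unreadable in the same way, a step that the limit leaves unreadable from compound 3 to compound 4, since the parallel step that the two limits leave unreadable from compound 1 to compound 2 could not be sized either. Compound 4 is therefore expected to give 80000 nM in this assay, most probably again only as a limit.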

Compound 4, half-maximal inhibitory concentration: > 50000 nM
Compound 4: only a limit was reported; the forecaster's own chance of this, stated with the estimate: 85%; the middle value lies beyond the limit too.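

In this assay compound 4 gives > 50000 nM, which is a limit of the assay. No new step can be read between compound 3 and compound 4, because all the values rest on one limit: the limit of > 50000 nM in this assay, at which 4 of the 4 values shown sit.

The compounds shown leave open how far each of the four lies beyond that limit, and whether adding the methoxy group changes their activity at all.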